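Replacing the 1H-tetrazol-5-yl group of compound 2

The source may report more compounds than this note shows. Statements on the series, on what has been measured and on what is new or still open speak of the compounds shown alone.

Compound 1 `NC(=O)c1ccc(-c2nc3cccnc3n2C2CCCC2)cc1`: 8000 nM
Compound 2 `c1cnc2c(c1)nc(-c1ccc(-c3nnn[nH]3)cc1)n2C1CCCC1`: 765 nM

In a functional assay on MDA-MB-231 cells (Homo sapiens) for cytotoxicity, read by MTT assay, with a stated time of 24 h (a higher number here means a weaker inhibitor, a lower number a stronger inhibitor), compound 2 has the lower of the two numbers and is thus the stronger inhibitor. Compound 3 `c1cnc2c(c1)nc(-c1ccc(-c3nnco3)cc1)n2C1CCCC1` makes one change to compound 2: 1,3,4-oxadiazol-2-yl in place of 1H-tetrazol-5-yl on an aromatic carbon. Among the compounds with values here, only one measured step bears on this place, a 10-fold lower number from compound 1 to compound 2 (1.02 log units; beyond the scatter), and it is large. Within the data shown here, that step brought in the 1H-tetrazol-5-yl group, so losing this group may give back part of the gain, though no measured step covers the 1,3,4-oxadiazol-2-yl group. The expected change is a moderate rise, a 2.6-fold higher number from compound 2 to compound 3 (0.42 log units; beyond the scatter). Compound 3 is expected at 2000 nM, with an estimated range of 600 nM to 7000 nM.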

Compound 3, half-maximal inhibitory concentration: 87 nM
Beside the measured number, compound 3's estimate is 23-fold (1.36 log units) above it; the measured number lies below the stated range.
By their numbers in this assay, from the lowest: compound 3; then compound 2; then compound 1.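

In this assay the swap to the 1,3,4-oxadiazol-2-yl group gives an 8.8-fold lower number from compound 2 to compound 3 (0.94 log units; beyond the scatter) and shows that the 1H-tetrazol-5-yl group is not the best choice at this place, para to a large group. The ring that enters has no hydrogen-bond donor, so a donor here is not required for this activity. Against carbamoyl the same group gives a 92-fold lower number from compound 1 to compound 3 (1.96 log units; beyond the scatter) and is the largest step seen so far at this place. As far as these compounds go, whether a carboxylic acid or a thiazole ring here would match compound 3 stays open. No measurement shown explains why the 1,3,4-oxadiazol-2-yl group does better.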